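Trading a Trimethoxyphenyl Amine for Cyclohexyl: an Expectation

The compounds below may be only part of what the source reports. "The series", "measured", "known", "first", "only" and "open" are said of these compounds alone.

Of the compounds shown here, three sharing one core have been tested in a functional assay on PC-3 cells (Homo sapiens) for cytotoxicity, read by MTT assay, with a stated time of 72 h; a higher number here means a weaker inhibitor, a lower number a stronger inhibitor. Compound 1 `N=C(Nc1cccc(C(F)(F)F)c1)c1cc2c(-c3ccccc3)n[nH]c2cn1` gives 19900 nM. Compound 2 `N=C(Nc1ccccc1)c1cc2c(-c3ccccc3)n[nH]c2c(NC2CCCCC2)n1`, which carries a cyclohexyl group on the ring nitrogen, gives 1730 nM. Compound 3 `COc1cc(Nc2nc(C(=N)Nc3cccc(C(F)(F)F)c3)cc3c(-c4ccccc4)n[nH]c23)cc(OC)c1OC` gives 13900 nM. Among these three numbers compound 3 stands second highest: its value and that of compound 1 lie within the usual scatter of each other, whereas compound 2 sits clearly lower, beyond the scatter. Compound 4 `N=C(Nc1cccc(C(F)(F)F)c1)c1cc2c(-c3ccccc3)n[nH]c2c(NC2CCCCC2)n1` has not been measured yet. It differs from compound 3 in one place: cyclohexyl in place of 3,4,5-trimethoxyphenyl on a nitrogen on an aromatic ring. Among the compounds with values here, no measured pair isolates this exact change, so the expectation rests on compound 2, which carries the same cyclohexyl group together with a plain phenyl on the amidine. Compound 4 is expected to come out as a stronger inhibitor in this assay with a step of a 4.6-fold lower number from compound 3 to compound 4 (0.67 log units; beyond the scatter) beyond the scatter, because compound 2 with the same cyclohexyl group gives 1730 nM. The estimate for compound 4 is 3000 nM, with a likely range from 1000 nM to 10000 nM.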

Compound 4, half-maximal inhibitory concentration: 25000 nM
Beside the measured number, compound 4's estimate is 8.3-fold (0.92 log units) below it; the measured number lies above the stated range.
By their numbers in this assay, from the lowest: compound 2; then compounds 3, 1 and 4 (each within the scatter of the next).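

In this assay, cyclohexyl in place of 3,4,5-trimethoxyphenyl on the nitrogen gives a 1.8-fold higher number from compound 3 to compound 4 (0.25 log units; within the scatter), so with trifluoromethyl present, this swap makes no measurable difference, even though the group entering is the smaller of the two. Adding cyclohexylamino in place of hydrogen on an aromatic carbon gives a 1.3-fold higher number from compound 1 to compound 4 (0.10 log units; within the scatter), so this position can also carry that group, or no group at all, without a clear change in this pair. The low number does not follow cyclohexyl alone, since trifluoromethyl in place of hydrogen on an aromatic carbon gives a 14-fold higher number from compound 2 to compound 4 (1.16 log units; beyond the scatter), a large step.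

Nothing available explains the size of that step. Still open, on these data alone, is whether a chlorine or a methoxy group on that aromatic carbon would also raise the number, and whether 3,4,5-trimethoxyphenyl would match cyclohexyl without the trifluoromethyl.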